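Swapping tert-butoxy for cyclopropyl on the side chain

The source may report more compounds than this note shows. Statements on the series, on what has been measured and on what is new or still open speak of the compounds shown alone.

Compound 1 `O=C(NCc1cc(Cl)ccc1-n1cnnn1)[C@@H]1[C@H]2C[C@H]2CN1C(=O)[C@H](O)Cn1cccn1`: 0.31 10^-6 cm/s
Compound 2 `CC(C)(C)OC[C@@H](O)C(=O)N1C[C@@H]2C[C@@H]2[C@H]1C(=O)NCc1cc(Cl)ccc1-n1cnnn1`: 17 10^-6 cm/s

In an ADME assay on Caco-2 cells (Homo sapiens) for permeability, read by LC-MS, in the apical to basolateral direction, with a stated time of 60 min, at pH 6.5 (a higher number here means that the compound crosses the layer faster, a lower number that the compound crosses the layer more slowly), compound 2 holds the higher of the two numbers, at 17 10^-6 cm/s, and compound 1 lies far under it. The next compound to be measured is compound 3 `O=C(NCc1cc(Cl)ccc1-n1cnnn1)[C@@H]1[C@H]2C[C@H]2CN1C(=O)[C@H](O)CC1CC1`. It differs from compound 2 as follows: cyclopropyl in place of tert-butoxy on a saturated chain carbon, two bonds along the chain from a carbonyl carbon and an oxygen on a saturated carbon. In words, cyclopropyl stands in place of tert-butoxy on a saturated chain carbon, two bonds along the chain from a carbonyl carbon and an oxygen on a saturated carbon.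

Among the compounds with values here, one measured step touches this same place: a 55-fold higher number from compound 1 to compound 2 (1.74 log units; beyond the scatter). That step is large and shows that a change here can move the number strongly. It involves tert-butoxy and 1H-pyrazol-1-yl, however, so the data say nothing directly about cyclopropyl. A moderate fall is therefore expected rather than a collapse to the level of compound 1, with a wide margin of doubt. The expected step is a 2.8-fold lower number from compound 2 to compound 3 (0.45 log units; beyond the scatter). The estimate for compound 3 is 6 10^-6 cm/s, with an expected range of 1.5 10^-6 cm/s to 20 10^-6 cm/s.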

Compound 3, apparent permeability: 3.4 10^-6 cm/s
The estimate for compound 3 lay 1.8-fold (0.25 log units) above the measured number; measured number inside the range.
By their numbers in this assay, from the lowest: compound 1; then compound 3; then compound 2.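

In this assay, this position now has three groups to compare, and cyclopropyl falls at neither end. Replacing tert-butoxy with cyclopropyl gives a 5.0-fold lower number from compound 2 to compound 3 (0.70 log units; beyond the scatter), while replacing 1H-pyrazol-1-yl with cyclopropyl gives an 11-fold higher number from compound 1 to compound 3 (1.04 log units; beyond the scatter), so both of these steps lie beyond the usual scatter and the three groups are clearly separated. The large rise first seen at this place is therefore not unique to tert-butoxy, although no outside evidence bears on why the groups fall in this order.

Tert-butoxy and cyclopropyl differ at once in heavy-atom count, in the presence of a ring and in the presence of an oxygen, so the compounds shown cannot tell which of these differences matters; a tert-butyl or a methoxy group at this place would begin to pull them apart. On these data alone, it also remains open how an amine or a carboxylic acid on this chain would compare with these three groups in this assay.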